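Moving the Pyridine Nitrogen in a Nucleotide Agonist

This account rests on a few compounds, and the source may have more. Where it says the series, first, only, none or still open, it means among the compounds named here.

Compound 1, `O=c1[nH]/c(=N\OCCCc2cccc(I)c2)ccn1[C@@H]1O[C@H](COP(=O)(O)OP(=O)(O)OP(=O)(O)O)[C@@H](O)[C@H]1O`: in a functional assay on 1321-N1 cells for agonist activity at P2Y purinoceptor 6 (Homo sapiens), read by scintillation counting and inositol phosphate accumulation (on this read-out lower numbers stand for an effect already at smaller amounts and higher numbers for an effect only at larger amounts of compound), compound 1 gives 299 nM.
Compound 2, `O=c1[nH]/c(=N\OCCCc2cccnc2)ccn1[C@@H]1O[C@H](COP(=O)(O)OP(=O)(O)OP(=O)(O)O)[C@@H](O)[C@H]1O`: in this assay compound 2 gives 2950 nM.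

Compound 2 stands at the higher of the two numbers. Going by the values given here, the only measured step, a 9.9-fold higher number from compound 1 to compound 2 (0.99 log units; beyond the scatter), concerns a different exchange. Compound 3, `O=c1[nH]/c(=N\OCCCc2ccncc2)ccn1[C@@H]1O[C@H](COP(=O)(O)OP(=O)(O)OP(=O)(O)O)[C@@H](O)[C@H]1O`, differs from compound 2 by pyridin-4-yl in place of pyridin-3-yl on a saturated chain carbon, three bonds along the chain from an oxygen. Among the compounds with values here, no measured step of this kind exists, so the prior step gives no direct guide, and no change beyond the scatter is expected. Compound 3 is therefore expected to sit near its parent, with a step of a 1.0-fold higher number from compound 2 to compound 3 (0.01 log units; within the scatter), an estimate of 3000 nM in this assay, ranging from 1000 nM to 9000 nM.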

Compound 3, half-maximal effective concentration: 4280 nM
Beside the measured number, compound 3's estimate is 1.4-fold (0.15 log units) below it; the measured number falls inside the stated range.
By their numbers in this assay, from the lowest: compound 1; then compounds 2 and 3 (each within the scatter of the next).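

In this assay, exchanging pyridin-3-yl for pyridin-4-yl gives a 1.5-fold higher number from compound 2 to compound 3 (0.16 log units; within the scatter), so the two pyridines cannot be told apart at this place on the chain. Pyridin-4-yl in place of 3-iodophenyl gives a 14-fold higher number from compound 1 to compound 3 (1.16 log units; beyond the scatter), so the gap first seen with pyridin-3-yl holds for both pyridines. Nothing available explains this gap. Still open, from the compounds shown here alone, is whether pyridin-2-yl would fall with these two pyridines, and whether a phenyl ring carrying an amine or a carboxylic acid would match 3-iodophenyl or the pyridines.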